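Thiophene replaces methoxyphenyl in a pyrazoline thiourea series

This account rests on a few compounds, and the source may have more. Where it says the series, first, only, none or still open, it means among the compounds named here.

Measured compounds:
Compound 1 `S=C(Nc1ccccc1)N1N=C(c2ccc(Br)cc2)CC1c1ccc2c(c1)OCCO2`, 2580 nM
Compound 2 `COc1ccccc1C1=NN(C(=S)Nc2ccccc2)C(c2ccc3c(c2)OCCO3)C1`, 30500 nM

In a functional assay on HT-29 cells (Homo sapiens) for antiproliferative activity, read by MTT assay, with a stated time of 48 h (on this read-out higher numbers stand for weaker inhibition of growth and lower numbers for stronger inhibition of growth), compound 2 gives 30500 nM, the highest number of the two measured. Its nearest neighbour is compound 1, which in this assay gives 2580 nM. These two share the same core and differ only in the aromatic group on the carbon that carries the double bond to nitrogen; the step of a 12-fold higher number from compound 1 to compound 2 (1.07 log units; beyond the scatter) shows that this position matters a great deal.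

Compound 3 `S=C(Nc1ccccc1)N1N=C(c2cccs2)CC1c1ccc2c(c1)OCCO2` changes that same position again: thiophen-2-yl in place of 2-methoxyphenyl on a carbon with a double bond to nitrogen. Within the data shown here, the only measured step that bears on this change is the one from compound 1 to compound 2, and it was large. A small five-membered ring without the methoxy substituent is a different group from either measured one, so the direction is uncertain, but since the 2-methoxyphenyl of compound 2 gave the weakest inhibition, its removal is expected to bring the number down. Compound 3 is therefore estimated at 7000 nM, with a range of 2000 nM to 25000 nM, a step of a 4.4-fold lower number from compound 2 to compound 3 (0.64 log units; beyond the scatter).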

Compound 3, concentration for 50% growth inhibition: 188000 nM
Compound 3: middle estimate off by 27-fold (1.43 log units), on the low side; the whole stated range lies below it.
By their numbers in this assay, from the lowest: compound 1; then compound 2; then compound 3.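

In this assay, the 2-methoxyphenyl group turns out not to be the worst group tested at this position: exchanging it for thiophen-2-yl weakens growth inhibition further (a 6.2-fold higher number from compound 2 to compound 3 (0.79 log units; beyond the scatter)). Measured against the best of the three groups, the loss is much larger (a 73-fold higher number from compound 1 to compound 3 (1.86 log units; beyond the scatter)), so the three compounds now span a wide range through this one position alone, in the order 4-bromophenyl, 2-methoxyphenyl, thiophen-2-yl from strongest to weakest inhibition. Both six-membered aromatic rings give lower numbers than the five-membered ring with sulfur, although a single thiophene compound is too little to establish a rule, and nothing available explains the result.

Going by these compounds, the step from compound 2 to compound 3 changes the ring size, the ring atoms and the methoxy substituent all at once, so the share of each in the loss remains unknown. An unsubstituted phenyl ring would separate the effect of the bromine and methoxy substituents from that of the ring itself, and furan-2-yl would show whether the sulfur atom matters or the five-membered ring as such.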